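This account rests on a few compounds, and the source may have more. Where it says the series, first, only, none or still open, it means among the compounds named here.

In an ADME assay on RAW264.7 cells (Mus musculus) for cytotoxicity, read by MTT assay, with a stated time of 72 h, tested at 50 uM (on this read-out higher numbers stand for more inhibition at the one concentration tested (going by the name of the read-out) and lower numbers for less inhibition), three compounds have been measured: compound 1 `CCOC(=O)c1sc(-c2ccccc2)nc1N1CCC(NCc2ccc(F)cc2)CC1` gives 6.23%; compound 2 `CCOC(=O)c1sc(-c2ccccc2)nc1N1CCC(NCc2ccc(OC)cc2)CC1` gives 8.4%; compound 3 `CCOC(=O)c1sc(-c2ccncc2)nc1N1CCC(NCc2ccc(F)cc2)CC1` gives 17.5%.

Compound 2 differs from compound 1 by methoxy in place of fluoro on an aromatic carbon, and this change gave a number 2.2 percentage points higher from compound 1 to compound 2 (within the scatter). The two cores differ by pyridin-4-yl in place of phenyl on an aromatic carbon, a change that gave a number 11.3 percentage points higher from compound 1 to compound 3 (beyond the scatter). Compound 3 therefore stands highest of the three numbers, though its gap to compound 2 is within the scatter and only its gap to compound 1 lies beyond it.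

Compound 4 `CCOC(=O)c1sc(-c2ccncc2)nc1N1CCC(NCc2ccc(OC)cc2)CC1` has not yet been measured. It differs from compound 3 by methoxy in place of fluoro on an aromatic carbon, which is the same change as that from compound 1 to compound 2, made on the other core. Because a number 2.2 percentage points higher from compound 1 to compound 2 (within the scatter) stayed within the scatter, the step from compound 3 to compound 4 in this assay is expected to be similarly small, estimated as a number 2.2 percentage points higher from compound 3 to compound 4 (within the scatter). On that basis compound 4 is estimated to give about 19.7% in this assay, most likely between 8% and 32%.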

Compound 4, a percentage reported as inhibition, at one concentration (the size of the read-out at that concentration, not a potency): 16.1%
For compound 4 the middle estimate is 3.6 percentage points above the measured one; the range from low to high includes it.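

Methoxy in place of fluoro on an aromatic carbon gave, in this assay, a number 1.4 percentage points lower from compound 3 to compound 4 (within the scatter), so on neither core did this change move the read-out beyond the scatter: the same change on two cores in this assay, a number 2.2 percentage points higher (within the scatter) from compound 1 to compound 2 and a number 1.4 percentage points lower (within the scatter) from compound 3 to compound 4, 3.6 percentage points apart, within the scatter of two such steps

Pyridin-4-yl in place of phenyl on an aromatic carbon gave a number 7.7 percentage points higher from compound 2 to compound 4 (within the scatter), and although the same change with fluoro in place lay beyond the scatter, the two steps do not differ by more than the scatter: the same change on two cores in this assay, a number 11.3 percentage points higher (beyond the scatter) from compound 1 to compound 3 and a number 7.7 percentage points higher (within the scatter) from compound 2 to compound 4, 3.6 percentage points apart, within the scatter of two such steps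

This shows that, across these four compounds, each change carried from one core to the other without a detectable difference, but it does not show that the steps are identical, and a small dependence on the core cannot be excluded.

The compounds shown leave open whether a chloro or nitrile in place of fluoro or methoxy, or a carboxylic acid or amide in place of the ethyl ester, would follow the same course. With only one concentration tested, they also leave open how the compounds would compare across a range of concentrations.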